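This account rests on a few compounds, and the source may have more. Where it says the series, first, only, none or still open, it means among the compounds named here.

The compounds measured so far:
Compound 1 `CC(C)(C)n1nc(Oc2cc(O)ccn2)c2c(N)ncnc21` — in an ADME assay on microsomes from liver (Homo sapiens) for metabolic stability, read by LC-MS, using NADPH, with a stated time of 10 min, tested at 10 uM (a higher number here means that the compound lasts longer, a lower number that the compound disappears faster), compound 1 gives 1.4 h.
Compound 2 `Nc1ncnc2c1c(Oc1cc(C(F)(F)F)ccn1)nn2[C@H]1CC[C@@H](N)CC1` — in this assay compound 2 gives > 2.41 h, which is a limit of the assay and not a number.
Compound 3 `CC(C)(C)n1nc(Oc2cc(C#N)ccn2)c2c(N)ncnc21` — in this assay compound 3 gives > 2.41 h, again a limit of the assay.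

Compound 2 thus stands at the limit of > 2.41 h in this assay, at which 2 of the 3 values shown sit, so its true half-life is not pinned down by the numbers shown. The single measured step among these compounds, an at least 1.7-fold higher number from compound 1 to compound 3 (0.23 log units; that floor lies within the scatter), concerns a group on the aromatic carbon and not the place that changes here. Compound 4 `Nc1ncnc2c1c(Oc1cc(C(F)(F)F)ccn1)nn2[C@@H]1CCCC[C@H]1O` differs from compound 2 in one place: 2-hydroxycyclohexyl in place of 4-aminocyclohexyl on an aromatic nitrogen. For the measured compounds named here, no measured step bears on this change, and so there is no ground for expecting a shift in this assay beyond the scatter in either direction. Compound 4 is therefore expected to give about 2.4 h, in a range from 1.2 h to 4.5 h. The estimated step of a number no higher from compound 2 to compound 4 (the limit leaves the size open) is expected to lie within the scatter.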

Compound 4, half-life: > 2.41 h
Compound 4 ended at the assay's limit; the forecaster's own chance of this, stated with the estimate: 55%; middle value at least 1.0-fold (0.00 log units) away from the limit.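

In this assay, for the compounds shown here, compound 2 and compound 4 both give limits of the assay and not numbers, so no step between them can be read. The compounds shown leave open whether 2-hydroxycyclohexyl in place of 4-aminocyclohexyl changes the half-life at all.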